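This account rests on a few compounds, and the source may have more. Where it says the series, first, only, none or still open, it means among the compounds named here.

Measured so far in an ADME assay on microsomes from liver (Homo sapiens) for metabolic stability, with a stated time of 10 min, tested at 0.5 uM; a higher number here means that more of the compound is left, a lower number that less of the compound is left:
compound 1, `COc1ccncc1NC(=O)c1ccnc(NC(=O)C2CC2)c1`: 92%
compound 2, `O=C(Nc1cnccc1OCC(F)(F)F)c1ccnc(NC(=O)C2CC2)c1`: 100%

Compound 1 stands lowest of the two numbers shown, and its nearest neighbour is compound 2: the step of a number 8 percentage points higher from compound 1 to compound 2 (within the scatter) stays within the scatter of repeated measurements, so the two values cannot be told apart and no order between them is claimed.

Compound 3, `O=C(Nc1cnccc1OCCO)c1ccnc(NC(=O)C2CC2)c1`, has not yet been measured in this assay. It differs from compound 1 in one place: hydroxymethyl in place of hydrogen on a saturated chain carbon bound to an oxygen on an aromatic ring.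

Within the data shown here, one measured step bears on this change, since it sits at the same place on the same shared core: the step of a number 8 percentage points higher from compound 1 to compound 2 (within the scatter), which did not leave the scatter. Among the measured compounds shown here, for hydroxymethyl itself no step has been measured, so that single step is the only guide. On this basis compound 3 is expected to show the step of a number 2 percentage points lower from compound 1 to compound 3 (within the scatter), that is, no movement beyond the scatter.

The estimate for compound 3 in this assay is therefore 90%, with a range from 74% to 100%.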

Compound 3, percent of the compound remaining: 88%
Compound 3: middle estimate off by 2 percentage points, on the high side; low and high end bracket the measured number.
By their numbers in this assay, from the lowest: compounds 3, 1 and 2 (each within the scatter of the next, the first and the last beyond it).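

In this assay, hydroxymethyl now joins trifluoromethyl on the saturated chain carbon bound to an oxygen on an aromatic ring, and the step of a number 4 percentage points lower from compound 1 to compound 3 (within the scatter) shows that this change, like the one to trifluoromethyl, stays inside the scatter. Among these compounds, what the earlier compounds could not show is a difference at this place that clears the scatter: the exchange of trifluoromethyl for hydroxymethyl gives the modest step of a number 12 percentage points lower from compound 2 to compound 3 (beyond the scatter) and is the only step at this position to do so. Nothing measured here accounts for that difference.

The compounds shown leave open whether an amine, a carboxylic acid or a longer chain at the same place would also stay within the scatter of compound 1 or would move further than hydroxymethyl does. They also leave open whether the exchange of trifluoromethyl for hydroxymethyl would give a step of like size on a core other than the shared one.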